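This account rests on a few compounds, and the source may have more. Where it says the series, first, only, none or still open, it means among the compounds named here.

Compound 1, `COc1cc(NC(C)CCCNC(=O)NNC(=O)N(CCO)CCO)c2ncccc2c1`, in a physicochemical assay for inhibition, read by spectrophotometry, tested at 100 uM; a lower number here means less inhibition, a higher number more inhibition at the concentration tested (going by the name of the read-out): 43%
Compound 2, `COc1cc(NC(C)CCCNC(=O)Nc2ccc(Cl)c(C(F)(F)F)c2)c2ncccc2c1`, in this assay: 61%

Compound 1 stands lowest of these two numbers in this assay. Compound 3, `COc1cc(NC(C)CCCNC(=O)NNC(=O)Nc2ccc(Cl)c(C(F)(F)F)c2)c2ncccc2c1`, is not yet measured; it differs from compound 1 by (4-chloro-3-(trifluoromethyl)phenyl)amino in place of bis(2-hydroxyethyl)amino on a carbonyl carbon. Going by the values given here, the one measured step that bears on this change is a number 18 percentage points higher from compound 1 to compound 2 (beyond the scatter), where the same aryl group enters, though in place of a different part of compound 1. For compound 3 a step in the same direction is therefore expected, a number 13 percentage points higher from compound 1 to compound 3 (beyond the scatter). Compound 3 is estimated at 56%, with a range from 38% to 74%.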

Compound 3, a percentage reported as inhibition, at one concentration (the size of the read-out at that concentration, not a potency): 63%
Compound 3: the middle estimate sits 7 percentage points below what was measured; low and high end bracket the measured number.
By their numbers in this assay, from the lowest: compound 1; then compounds 2 and 3 (each within the scatter of the next).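

In this assay, putting (4-chloro-3-(trifluoromethyl)phenyl)amino in place of bis(2-hydroxyethyl)amino on the carbonyl carbon gives a number 20 percentage points higher from compound 1 to compound 3 (beyond the scatter). Here the rest of compound 1 stays intact, including the amide-type nitrogen on that carbonyl, so the rise goes with this one exchange of end groups alone. Nothing measured here explains the rise.

Going by these compounds, whether the chlorine, the trifluoromethyl or the aromatic ring itself carries the change remains open. So does the outcome with a plain phenylamino or a small dimethylamino group on this carbonyl carbon.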